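A few compounds are considered here, and "the series" means these few. Any claim that something is new, unique, unknown or untested is made for them only; others in the source may bear on it.

In a functional assay on Jurkat cells (Homo sapiens) (on this read-out lower numbers stand for stronger inhibition and higher numbers for weaker inhibition), compound 1 `CC(C)[C@H](NC(=O)COc1cccc2ccccc12)C(=O)N[C@@H](CC(=O)O)C(=O)COc1ccccc1`, with a plain phenyl on an oxygen on a saturated carbon, gives 14000 nM. Compound 2 `CC(C)[C@H](NC(=O)COc1cccc2ccccc12)C(=O)N[C@@H](CC(=O)O)C(=O)COc1c(F)ccc(F)c1F`, with 2,3,6-trifluorophenyl at that place, gives 1200 nM, the lower of the two numbers. Compound 3 `CC(C)[C@H](NC(=O)COc1cccc2ccccc12)C(=O)N[C@@H](CC(=O)O)C(=O)COc1cc(F)cc(F)c1F` changes the same group again: 2,3,5-trifluorophenyl in place of 2,3,6-trifluorophenyl on an oxygen on a saturated carbon. Among the measured compounds shown here, only one measured step bears on this, a 12-fold lower number from compound 1 to compound 2 (1.07 log units; beyond the scatter), which is large and falls at the same place. That step introduced fluorine, however, while the new change keeps the fluorines and only rearranges them, from 2,3,6-trifluorophenyl to 2,3,5-trifluorophenyl. For the measured compounds named here, no measured pair shows what such a rearrangement does. A much smaller change is therefore expected, perhaps giving back a little of the gain seen in a 12-fold lower number from compound 1 to compound 2 (1.07 log units; beyond the scatter). In this assay the estimated change is a 1.6-fold higher number from compound 2 to compound 3 (0.20 log units; within the scatter). For compound 3 the expected value is 1900 nM, with an estimated range of 630 nM to 5700 nM.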

Compound 3, half-maximal inhibitory concentration: 30000 nM
Beside the measured number, compound 3's estimate is 16-fold (1.20 log units) below it; measured number outside the range, above it.
By their numbers in this assay, from the lowest: compound 2; then compound 1; then compound 3.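

In this assay, the fluorines on this ring do not act through their presence alone. With the same atoms and the same counts, 2,3,5-trifluorophenyl in place of 2,3,6-trifluorophenyl gives a 25-fold higher number from compound 2 to compound 3 (1.40 log units; beyond the scatter), so a rearrangement alone can produce a large step at this position. Three fluorines also do not guarantee any gain over the plain phenyl, as replacing that phenyl with 2,3,5-trifluorophenyl gives a 2.1-fold higher number from compound 1 to compound 3 (0.33 log units; beyond the scatter), and nothing available explains why the arrangement matters so much.

These three rings do not reveal which fluorine, if any single one, accounts for the difference between compound 2 and compound 3. As far as these compounds go, it also remains open how a ring with a different substitution, such as pentafluorophenyl or a chlorophenyl, would fare on this oxygen.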